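Heteroaryl amide swap tested for agonist efficacy

The compounds below may be only part of what the source reports. "The series", "measured", "known", "first", "only" and "open" are said of these compounds alone.

Measured compounds:
compound 1, `CC(C)[C@H](C(=O)Nc1ccc(F)cn1)c1ccc(Cl)cc1`, 93%
compound 2, `CC(C)C(C(=O)Nc1ncccn1)c1ccc(Cl)cc1`, 50%

Compound 1 gives the higher of the two numbers in a functional assay on CHO cells for agonist activity at Free fatty acid receptor 2 (Homo sapiens), read by cAMP accumulation; on this read-out higher numbers stand for larger maximal responses and lower numbers for smaller maximal responses. Among the compounds with values here, the only other measured compound, compound 2, shows a value that is lower by a gap beyond the usual scatter; since the two structures differ in more than one place, nothing more is drawn from that pair than what the two values show.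

Compound 3, `CC(C)[C@H](C(=O)Nc1ncc(C#N)s1)c1ccc(Cl)cc1`, has not yet been measured in this assay. It keeps the core of compound 1 and changes only the group on the amide-type nitrogen: 5-cyano-1,3-thiazol-2-yl in place of 5-fluoropyridin-2-yl on an amide-type nitrogen. Within the data shown here, no measured pair isolates a change at this position, so the expected size of the step rests on compound 1 alone.

The account expects a modest downward step, a number 13 percentage points lower from compound 1 to compound 3 (beyond the scatter), with compound 1 at 93% as the anchor and room for a loss of maximal response that could still stay within scatter. For compound 3 the estimate in this assay is 80%, between 55% and 100%.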

Compound 3, largest response reached (reported as efficacy), in percent of the reference or control that the assay uses: 105%
The estimate for compound 3 lay 25 percentage points below the measured number; measured number above the stated range.
By their numbers in this assay, from the lowest: compound 2; then compound 1; then compound 3.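

Within the data shown here, compound 3 gives the first step in which only the group on the amide-type nitrogen changes, with the core of compound 1 held fixed. In this assay, putting 5-cyano-1,3-thiazol-2-yl in place of 5-fluoropyridin-2-yl gives a number 12 percentage points higher from compound 1 to compound 3 (beyond the scatter), so at this position a five-membered aromatic ring bearing a nitrile not only keeps the maximal response of the six-membered fluorinated ring but modestly raises it. No measurement shown here accounts for this rise.

The ring and its substituent change together in this single step, so the compounds shown do not tell how much of the step belongs to the five-membered ring and how much to the nitrile. Also open, from the compounds shown here alone, is how the response in this assay would move with an unsubstituted 1,3-thiazol-2-yl group on the same nitrogen, or with a carboxylic acid or an amine in place of the nitrile on the 1,3-thiazol-2-yl ring.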